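A few compounds are considered here, and "the series" means these few. Any claim that something is new, unique, unknown or untested is made for them only; others in the source may bear on it.

compound 1 (`CCCN(C)c1nc(Cc2c(F)cccc2F)cc(=O)[nH]1`): 85000 nM
compound 2 (`CCCN(CCC)c1nc(Cc2c(F)cccc2F)cc(=O)[nH]1`): > 78000 nM (a limit)
compound 3 (`O=c1cc(Cc2c(F)cccc2F)nc(N2CCCCC2)[nH]1`): > 82000 nM (a limit)

Among the measured compounds shown here, in an ADME assay on MT4 cells (Homo sapiens) for cytotoxicity, read by MTT assay, with a stated time of 4 days (a higher number here means that more compound is tolerated, a lower number that less compound is tolerated), compound 1 gives 85000 nM as the only actual number. Compound 2 gives > 78000 nM as a limit. Compound 3 gives > 82000 nM as a limit too. Compound 1 therefore cannot be ranked against either neighbour.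

The step to compound 4 (`CCCN(C)c1nc(Cc2c(F)cccc2F)c(C)c(=O)[nH]1`) is methyl in place of hydrogen on an aromatic carbon and puts a methyl in place of hydrogen on an aromatic carbon of the shared core. For the measured compounds named here, no measured step touches that carbon. The three measured steps all change the amino group instead: a step that the limit leaves unreadable from compound 1 to compound 2 and a step that the limit leaves unreadable from compound 1 to compound 3 and a step that the two limits leave unreadable from compound 2 to compound 3 all lack a readable size. They give no measured size to carry over to the new methyl.

In this assay the starting point is compound 1 at 85000 nM. With no evidence for a shift, no step beyond the usual scatter is expected from it. The expected change, a 1.1-fold lower number from compound 1 to compound 4 (0.05 log units; within the scatter), is an estimate that stays small. Compound 4 is estimated at 75000 nM with an expected range from 35000 nM to 100000 nM for this measurement.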

Compound 4, half-maximal cytotoxic concentration: > 81000 nM
Compound 4: no number, only a limit; the forecaster's own chance of this, stated with the estimate: 55%; middle value at least 1.0-fold (0.03 log units) away from the limit.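

In this assay compound 4 gives > 81000 nM, which is a limit and not a number. The step from compound 1 to compound 4 therefore has no readable size. The compounds shown leave open whether methyl in place of hydrogen on this aromatic carbon shifts the tolerated concentration at all, and how compound 4 ranks against compound 1.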